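Chloro in Place of Hydrogen on the Core of Compound 1

The source may hold more compounds than are shown below. What is called first, only, known or untested is meant among the compounds shown, and "the series" means these compounds.

Measured compounds:
compound 1 `CC(C)(C)OC(=O)/C=C1/C(=O)Nc2ccccc21`: 64.1%
compound 2 `COc1ccc2c(c1)NC(=O)/C2=C/C(=O)OC(C)(C)C`: 63.6%

Both values come from a toxicity assay on L02 cells (Homo sapiens) for inhibition, read by CCK-8 assay, with a stated time of 72 h, tested at 20 uM; a lower number here means less inhibition of growth, a higher number more inhibition of growth at the concentration tested. Compound 1 and compound 2 sit side by side on these numbers: the step of a number 0.5 percentage points lower from compound 1 to compound 2 (within the scatter) is too small to separate them, so neither can be called the more inhibitory of the two.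

Compound 3 `CC(C)(C)OC(=O)/C=C1/C(=O)Nc2ccc(Cl)cc21` has not yet been measured. It differs from compound 1 in one place: chloro in place of hydrogen on an aromatic carbon. Among the measured compounds shown here, the only measured step that bears on it is the one from compound 1 to compound 2, where a methoxy in place of hydrogen on an aromatic carbon left the number essentially unchanged. For the measured compounds named here, a chloro entering at a different aromatic carbon is a different change, and no measured pair shows its effect here, so the expectation rests on the near-flat single step available.

Compound 3 is therefore expected to show 63% in this assay, within 50% to 76%, a step of a number 1.1 percentage points lower from compound 1 to compound 3 (within the scatter) that is estimated to stay inside the scatter.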

Compound 3, percent growth inhibition at one concentration: 63.3%
For compound 3 the middle estimate is 0.3 percentage points below the measured one; the measured number falls inside the stated range.
By their numbers in this assay, from the lowest: compounds 3, 2 and 1 (each within the scatter of the next).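

In this assay, chloro in place of hydrogen on this aromatic carbon, meta to a fused ring and para to a fused ring, gives a number 0.8 percentage points lower from compound 1 to compound 3 (within the scatter). A single chlorine atom at this position therefore cannot be told apart from hydrogen in this read-out, and the chloro change now stands alongside the methoxy change, a number 0.5 percentage points lower from compound 1 to compound 2 (within the scatter), as a second substitution on the aromatic ring that does not separate from compound 1. Nothing available speaks to what lies behind this flat result.

On these data alone, whether an amine or a carboxylic acid on the same aromatic carbon would also stay within the scatter remains open. So does the effect of a longer chain in place of the amide hydrogen, away from the aromatic ring altogether.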